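The source may report more compounds than this note shows. Statements on the series, on what has been measured and on what is new or still open speak of the compounds shown alone.

Measured so far in a functional assay on HepG2 cells (Homo sapiens) for inhibition, read by CCK-8 assay, with a stated time of 48 h; a lower number here means a stronger inhibitor, a higher number a weaker inhibitor:
- compound 1 `c1ccc(C2=NN(C3=NC(c4ccccc4)CS3)C(c3cccc4ccccc34)C2)cc1`: 13200 nM
- compound 2 `O=C1CSC(N2N=C(c3ccc(Cl)cc3)CC2c2cccc3ccccc23)=N1`: 16500 nM
- compound 3 `c1ccc(C2=NN(C3=NC(c4ccccc4)CS3)C(c3ccc4ccccc4c3)C2)cc1`: 17200 nM

In this assay compound 3 gives 17200 nM, the largest of the three numbers, yet its gaps to compound 1 and to compound 2 both lie within the scatter, so the three cannot be told apart on these data.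

Compound 4 `Clc1ccc(C2=NN(C3=NC(c4ccccc4)CS3)C(c3ccc4ccccc4c3)C2)cc1` differs from compound 3 by chloro in place of hydrogen on an aromatic carbon; cut one bond further out, the change reads phenyl to 4-chlorophenyl. Among the compounds with values here, no measured step alters this group alone. Within the data shown here, the single step available, a 1.3-fold higher number from compound 1 to compound 3 (0.11 log units; within the scatter), concerns the attachment of the naphthyl group and does not bear on a chloro substituent. Compound 2 does carry a 4-chlorophenyl group, but it differs from compound 3 in other places as well; in this assay compound 2 gives 16500 nM, a number within the scatter of the value of compound 3. Nothing here points to a shift beyond the scatter. The step of a 1.1-fold lower number from compound 3 to compound 4 (0.06 log units; within the scatter) is therefore expected to stay within the scatter. Compound 4 is estimated at 15000 nM, with a range from 6000 nM to 40000 nM.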

Compound 4, half-maximal inhibitory concentration: 22100 nM
Estimate against measurement, compound 4: 1.5-fold (0.17 log units) below, within the range that was stated.
By their numbers in this assay, from the lowest: compounds 1, 2, 3 and 4 (each within the scatter of the next).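

In this assay, the position para to a large group on the six-membered aromatic ring now has its first direct reading: chloro in place of hydrogen gives a 1.3-fold higher number from compound 3 to compound 4 (0.11 log units; within the scatter) and so does not move the number beyond the scatter. Within the data shown here, with a 1.3-fold higher number from compound 1 to compound 3 (0.11 log units; within the scatter) as the only other step, neither of the two single-place changes read so far separates its pair of compounds, and the series remains flat at both places. No measurement on hand bears on this result.

Still open, from the compounds shown here alone, is whether a group of another kind at this position, such as an amine, a carboxylic acid or a longer chain, would give a step beyond the scatter. Going by these compounds, it is also open whether phenyl to 4-chlorophenyl reads the same with naphthalen-1-yl in place of naphthalen-2-yl on the saturated ring carbon.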